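Swapping Methoxy for a Larger Group on the Aromatic Ring

This account rests on a few compounds, and the source may have more. Where it says the series, first, only, none or still open, it means among the compounds named here.

Compound 1, `COc1ccc2c(c1)C(n1ccccc1=O)=CC(C)(C)O2`: 6.55
Compound 2, `CCC(=O)c1ccc2c(c1)C(n1ccccc1=O)=CC(C)(C)O2`: 6.63

In a functional assay (aorta) with Rattus norvegicus as the target (a lower number here means a less potent compound, a higher number a more potent compound, by a factor of ten per unit of this negative logarithm), compound 1 gives 6.55, the lowest of the two numbers; the nearest is compound 2 at 6.63. Among the measured compounds shown here, the only measured step, a number 0.08 log units higher from compound 1 to compound 2 (within the scatter), puts propanoyl in place of methoxy on an aromatic carbon and stays within the scatter.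

Compound 3, `CC1(C)C=C(n2ccccc2=O)c2cc(C(=N)NO)ccc2O1`, carries a group of 4 heavy atoms (1 carbon, 2 nitrogen, 1 oxygen; no ring) in place of a group of 2 heavy atoms (1 carbon, 1 oxygen; no ring), on an aromatic carbon. The step from compound 1 to compound 2 is the one that bears on this change, since it too replaces the methoxy at the same aromatic carbon, and it was small. The group entering in compound 3 is counted differently from propanoyl, so the precedent is loose, but it gives no sign of a large move in either direction.

For compound 3 a value of 6.5 is expected, within 5.8 to 7.2, so the estimated step of a number 0.05 log units lower from compound 1 to compound 3 (within the scatter) is not expected to exceed the scatter.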

Compound 3, logarithm of the reciprocal of the active concentration, log(1/C): 5.99
Estimate against measurement, compound 3: 0.51 log units above; low and high end bracket the measured number.
By their numbers in this assay, from the lowest: compound 3; then compounds 1 and 2 (each within the scatter of the next).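

This aromatic carbon does not accept every replacement equally in this assay: the group entering in compound 3 lowers the number relative to methoxy (a number 0.56 log units lower from compound 1 to compound 3 (beyond the scatter)) and relative to propanoyl (a number 0.64 log units lower from compound 2 to compound 3 (beyond the scatter)), whereas methoxy and propanoyl themselves stayed within the scatter of each other. Propanoyl and the entering group both hold 4 heavy atoms, so heavy-atom count alone does not separate compound 2 from compound 3, and the size of a group is not enough to predict the result here. No measurement is available that explains this loss.

Three compounds cannot show which feature of the entering group, such as its nitrogens or its 3 hydrogen-bond donors, goes with the lower number. As far as these compounds go, it also remains open whether an amine or a carboxylic acid on this same aromatic carbon would fall with compound 3 or with compounds 1 and 2.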